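A Smaller Open Chain in Place of Benzoylcarbamoyl

The compounds below may be only part of what the source reports. "The series", "measured", "known", "first", "only" and "open" are said of these compounds alone.

Measured in a functional assay on HEL cells (Homo sapiens); a lower number here means that less compound is tolerated, a higher number that more compound is tolerated:
Compound 1 `C=C(C)C(=O)NC(=O)NC1=CS(=O)(=O)O[C@@]12[C@@H](CO[Si](C)(C)C(C)(C)C)O[C@@H](n1cc(C)c(=O)n(C)c1=O)[C@@H]2O[Si](C)(C)C(C)(C)C`: 1200 nM
Compound 2 `Cc1cn([C@@H]2O[C@H](CO[Si](C)(C)C(C)(C)C)[C@@]3(OS(=O)(=O)C=C3NCCC(=O)O)[C@H]2O[Si](C)(C)C(C)(C)C)c(=O)n(C)c1=O`: 34000 nM
Compound 3 `Cc1cn([C@@H]2O[C@H](CO[Si](C)(C)C(C)(C)C)[C@@]3(OS(=O)(=O)C=C3NC(=O)NC(=O)c3ccccc3)[C@H]2O[Si](C)(C)C(C)(C)C)c(=O)n(C)c1=O`: >= 200000 nM (a limit of the assay)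

Compound 3 stands highest of the three, but only as a limit, and its >= 200000 nM is not a number. Compound 4 `Cc1cn([C@@H]2O[C@H](CO[Si](C)(C)C(C)(C)C)[C@@]3(OS(=O)(=O)C=C3NCC(=O)C(N)=O)[C@H]2O[Si](C)(C)C(C)(C)C)c(=O)n(C)c1=O` keeps the shared core and differs from compound 3 as follows: (carbamoylcarbonyl)methyl in place of benzoylcarbamoyl on an amine nitrogen. In words, (carbamoylcarbonyl)methyl takes the place of benzoylcarbamoyl on an amine nitrogen.

All three measured steps changed the group at this same place. The step of an at least 5.8-fold higher number from compound 2 to compound 3 (0.76 log units; beyond the scatter) was at least modest, while a 28-fold higher number from compound 1 to compound 2 (1.45 log units; beyond the scatter) and an at least 160-fold higher number from compound 1 to compound 3 (2.22 log units; beyond the scatter) were both large. Compound 2, at 34000 nM, is the nearest guide: its 2-carboxyethyl, like the entering group, holds no ring. Compound 1, at 1200 nM, shows how far a change at this place can move the number in this assay. A fall from the limit of compound 3 is therefore expected, of modest or larger size, though a limit leaves the true size open. The expected change is an at least 5.0-fold lower number from compound 3 to compound 4 (0.69 log units; beyond the scatter). Compound 4 is estimated at 40000 nM, with an expected range from 10000 nM to 150000 nM.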

Compound 4, half-maximal cytotoxic concentration: 14500 nM
Estimate against measurement, compound 4: 2.8-fold (0.44 log units) above, within the range that was stated.
By their numbers in this assay, from the lowest: compound 1; then compound 4; then compound 2. At a limit, above all of these: compound 3.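

Compound 3 holds a limit of the assay and not a number: the limit of >= 200000 nM in this assay, at which 1 of the 4 values shown sits.

In this assay, (carbamoylcarbonyl)methyl in place of benzoylcarbamoyl gives an at least 13-fold lower number from compound 3 to compound 4 (1.13 log units; beyond the scatter), which shows that this change moves the number a long way even though the counts of hydrogen-bond donors and acceptors stay the same. Compound 4 also separates two ring-free chains of similar form, with a 2.3-fold lower number from compound 2 to compound 4 (0.37 log units; beyond the scatter), a modest step that is still beyond the scatter, and this shows that a change at the far end of the chain can register here, while a 12-fold higher number from compound 1 to compound 4 (1.08 log units; beyond the scatter) shows that having no ring does not by itself set the number, since compound 1 also has a ring-free group and stands lowest of the four.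

The compounds shown leave open where a plain primary amine, a simple alkyl chain or a longer chain ending in a carbamoyl group would fall at this amine nitrogen. They also leave open the true distance of compound 3 from the others, and whether the order among these groups would hold on a core other than the shared one.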